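Pyridin-3-yl in place of 4-(trifluoromethyl)phenyl: cytotoxicity notes

The source may hold more compounds than are shown below. What is called first, only, known or untested is meant among the compounds shown, and "the series" means these compounds.

Measured in a functional assay on HEK293 cells (Homo sapiens) for cytotoxicity; a lower number here means that less compound is tolerated, a higher number that more compound is tolerated:
Compound 1 `COc1ccc([C@H]2CC(=O)N(c3ccccc3)C2)cc1OC1CCCC1` gives a limit (> 10000 nM)
Compound 2 `COc1ccc([C@H]2CC(=O)N(c3ccc(C(F)(F)F)cc3)C2)cc1OC1CCCC1` gives a limit (> 10000 nM)

Compound 2 stands only at a limit (> 10000 nM). Compound 3 (`COc1ccc([C@H]2CC(=O)N(c3cccnc3)C2)cc1OC1CCCC1`) carries pyridin-3-yl in place of 4-(trifluoromethyl)phenyl on an amide-type nitrogen in a ring. Among the compounds with values here, only one measured step bears on this change, and it is a step that the two limits leave unreadable from compound 1 to compound 2 and so offers no size to carry over. Both measured compounds share one limit (the limit of > 10000 nM in this assay, at which 2 of the 2 values shown sit). No readable step in either direction is therefore expected in this assay and compound 3 will most likely be reported as a limit too. The expected step is a step that the limit leaves unreadable from compound 2 to compound 3 and it rests on limits alone. The estimated value for compound 3 is 15000 nM with an expected range from 8000 nM to 40000 nM in this read-out.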

Compound 3, half-maximal cytotoxic concentration: > 10000 nM
Compound 3 ended at the assay's limit; the forecaster's own chance of this, stated with the estimate: 85%; the middle value does not contradict the limit.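

In this assay compound 3 gives > 10000 nM, which is a limit. No step among compound 1, compound 2 and compound 3 can be read, with all three at one limit: the limit of > 10000 nM in this assay, at which 3 of the 3 values shown sit.

The compounds shown leave open where the true values lie and whether the group on the amide-type nitrogen changes them at all.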